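Carboxy for ethylsulfamoyl on a biphenyl ether pair

The source may report more compounds than this note shows. Statements on the series, on what has been measured and on what is new or still open speak of the compounds shown alone.

Measured compounds:
compound 1 `CCOC(=O)c1ccc(-c2ccc(OCC)cc2)o1`, 93%
compound 2 `CCNS(=O)(=O)c1cccc(-c2ccc(OCC)cc2)c1`, 46%

The two measured compounds share an ethoxy-bearing ring joined to a second aromatic ring. In an assay on COS-7 cells for inhibition of patatin-like phospholipase domain-containing protein 2 (Mus musculus), tested at 200 uM (a higher number here means more inhibition at the concentration tested (going by the name of the read-out), a lower number less inhibition), compound 1 reaches 93%, whereas compound 2 gives 46%. Compound 2 thus holds the lowest of the two numbers, and its gap to compound 1 lies beyond the scatter of repeated runs.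

Compound 3 `CCOc1ccc(-c2cccc(C(=O)O)c2)cc1` is not yet measured. It differs from compound 2 in a single respect: carboxy in place of ethylsulfamoyl on an aromatic carbon. The new group sits on an aromatic carbon of a six-membered carbon ring, meta to a group of 9 heavy atoms. Within the data shown here, no pair of measured compounds differing in one place is available to calibrate this exchange, so the expectation for compound 3 rests on compound 2 alone. The step of a number 11 percentage points lower from compound 2 to compound 3 (beyond the scatter) is expected to be a modest fall, possibly no larger than the scatter. Compound 3 is therefore estimated at 35%, with a range from 10% to 65%.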

Compound 3, a percentage reported as inhibition, at one concentration (the size of the read-out at that concentration, not a potency): 23%
The estimate for compound 3 lay 12 percentage points above the measured number; measured number inside the range.
By their numbers in this assay, from the lowest: compound 3; then compound 2; then compound 1.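

At this aromatic carbon, meta to a group of 9 heavy atoms, this assay now has its first reading of a single exchange: carboxy in place of ethylsulfamoyl gives a number 23 percentage points lower from compound 2 to compound 3 (beyond the scatter). The number at this place therefore depends on the group that stands there, and here the carboxy, with 3 heavy atoms, does not hold the level seen with the ethylsulfamoyl, with 6 heavy atoms. Nothing at hand bears on why the step takes this direction or this size.

The two compounds cannot show whether a primary amine or a methyl ester on the same carbon would give a higher or a lower number. On these data alone, it also remains open whether a longer chain in place of the ethyl of the ethylsulfamoyl would shift the number, and in which direction.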